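A trifluoromethyl swap on a weak phenyl compound

The source may hold more compounds than are shown below. What is called first, only, known or untested is meant among the compounds shown, and "the series" means these compounds.

Compound 1 `C/C(=C\CC/C(C)=C/CC[C@@H]1[C@@]2(C)CCC(=O)C(C)(C)[C@H]2CC[C@@]1(C)O)CC/C=C(\C)C(=O)OCc1cn(C[C@@H]2O[C@H](n3ccc(=O)[nH]c3=O)C[C@H]2O)nn1` gives 26300 nM in a functional assay on MDA-MB-231 cells (Homo sapiens) for antiproliferative activity, read by MTT assay, with a stated time of 48 h (a lower number here means a stronger inhibitor, a higher number a weaker inhibitor), and is the only one of the three measured compounds to return a true number. Compound 3 `C/C(=C\CC/C(C)=C/CC[C@@H]1[C@@]2(C)CCC(=O)C(C)(C)[C@H]2CC[C@@]1(C)O)CC/C=C(\C)C(=O)OCc1cn(C[C@@H]2O[C@H](n3ccc(=O)[nH]c3=O)[C@H]3OC(C)(C)O[C@H]32)nn1` gives > 150000 nM in this assay and that reading is a limit of the assay, not a number. Compound 2 `C/C(=C\CC/C(C)=C/CC[C@@H]1[C@@]2(C)CCC(=O)C(C)(C)[C@H]2CC[C@@]1(C)O)CC/C=C(\C)C(=O)OCc1cn(-c2ccccc2C)nn1` gives > 150000 nM in this assay and that reading is likewise a limit. Compound 2 thus stands at the limit of > 150000 nM in this assay, at which 2 of the 3 values shown sit, and has no exact place on the scale.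

Compound 4 `C/C(=C\CC/C(C)=C/CC[C@@H]1[C@@]2(C)CCC(=O)C(C)(C)[C@H]2CC[C@@]1(C)O)CC/C=C(\C)C(=O)OCc1cn(-c2cccc(C(F)(F)F)c2)nn1` differs from compound 2 in one place, as 3-(trifluoromethyl)phenyl in place of 2-methylphenyl on an aromatic nitrogen shows. In words, it has 3-(trifluoromethyl)phenyl in place of 2-methylphenyl on an aromatic nitrogen. Among the measured compounds shown here, both compounds carry a substituted phenyl group there, but no measured pair shows what such a swap does on its own.

The expectation rests on compound 2 and its limit of > 150000 nM as the nearest reference. The estimated change is an at least 1.2-fold lower number from compound 2 to compound 4 (0.09 log units; that floor lies within the scatter) and is expected to stay within the usual scatter, with no firm direction. Another report of only a limit is quite possible. For compound 4 the estimated value is 120000 nM with an expected range from 40000 nM to 250000 nM if a true number is returned.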

Compound 4, half-maximal inhibitory concentration: > 150000 nM
Compound 4: no number, only a limit; the forecaster's own chance of this, stated with the estimate: 60%; at least 1.2-fold (0.09 log units) between middle value and limit.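

In this assay compound 4 gives > 150000 nM, which is a limit and not a number. Compound 2 gives > 150000 nM, also a limit, so no step can be read on going from compound 2 to compound 4. The compounds shown leave open whether swapping 2-methylphenyl for 3-(trifluoromethyl)phenyl changes antiproliferative activity at all.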